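A few compounds are considered here, and "the series" means these few. Any claim that something is new, unique, unknown or untested is made for them only; others in the source may bear on it.

Working notes on the series. Of the compounds shown here, three are measured so far: compound 1 `O=C1N=C(NN2Cc3ccccc3N=C2c2ccccc2)S/C1=C/c1ccc(O)cc1O`, compound 2 `O=C1N=C(NN2Cc3ccccc3N=C2c2ccccc2)S/C1=C/c1ccc(Br)cc1` and compound 3 `O=C(CNc1ccc(Cl)cc1Cl)Nn1c(-c2ccccc2)nc2ccccc2c1=O`. In a functional assay on MCF7 cells (Homo sapiens) for cytotoxicity, read by MTT assay, with a stated time of 4 h (a lower number here means a stronger inhibitor, a higher number a weaker inhibitor), compound 1 gives 7490 nM, compound 2 gives 2300 nM and compound 3 gives 4410 nM. Compound 3 thus stands second highest of the three numbers, and its value lies within the scatter of both compound 1 and compound 2, so nothing separates it from either. Within the data shown here, the one measured step is a 3.3-fold lower number from compound 1 to compound 2 (0.51 log units; beyond the scatter).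

Compound 4 `O=C(CNc1ccc(Br)cc1)Nn1c(-c2ccccc2)nc2ccccc2c1=O` is not yet measured. It differs from compound 3 in a single place: 4-bromophenyl in place of 2,4-dichlorophenyl on an amine nitrogen. Among the measured compounds shown here, the step from compound 1 to compound 2 is the only measured change that also brings in a 4-bromophenyl, but there it replaces a 2,4-dihydroxyphenyl on a double-bonded chain carbon bound to a double-bonded ring carbon, not a 2,4-dichlorophenyl on an amine nitrogen, so it bears on the present step only loosely. For the measured compounds named here, no measured step removes a 2,4-dichlorophenyl. For compound 4 the expected change in this assay is therefore small, a 1.4-fold lower number from compound 3 to compound 4 (0.14 log units; within the scatter), with a lower number slightly favoured given the direction of a 3.3-fold lower number from compound 1 to compound 2 (0.51 log units; beyond the scatter) but not expected to exceed the scatter. Compound 4 is estimated at 3200 nM in this assay, with a range from 1200 nM to 8500 nM.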

Compound 4, half-maximal inhibitory concentration: 15100 nM
Compound 4: middle estimate off by 4.7-fold (0.67 log units), on the low side, and the stated range ends below it.
By their numbers in this assay, from the lowest: compounds 2, 3, 1 and 4 (each within the scatter of the next, the first and the last beyond it).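

In this assay, the group on the amine nitrogen turns out to matter: a 3.4-fold higher number from compound 3 to compound 4 (0.53 log units; beyond the scatter), a step beyond the scatter for 4-bromophenyl in place of 2,4-dichlorophenyl. The only earlier step bringing in a 4-bromophenyl ran the other way, a 3.3-fold lower number from compound 1 to compound 2 (0.51 log units; beyond the scatter), so across the two steps shown this group carries no single direction; its effect depends on the group it replaces, the place it sits, or both. Nothing available bears on the cause of the higher number for compound 4.

The step changes the halogen and the substitution pattern of the ring at once, so the compounds shown do not say which of the two accounts for it. A 4-chlorophenyl on the same amine nitrogen would separate these two changes, and a 2-chloro-4-bromophenyl or an unsubstituted phenyl there would show whether the 2,4-dichlorophenyl of compound 3 holds any particular standing at this position.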